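Swapping a Bromo Chain End for an Ethyl Ester

The source may hold more compounds than are shown below. What is called first, only, known or untested is meant among the compounds shown, and "the series" means these compounds.

Measured in an ADME assay on L929 cells (Mus musculus) for cytotoxicity, read by resazurin assay, with a stated time of 48 h; a higher number here means that more compound is tolerated, a lower number that less compound is tolerated:
- Compound 1 `C=Cn1c2ccc([N+](=O)[O-])cc2c(=O)n1Cc1ccccc1`: 160000 nM
- Compound 2 `NC(=O)CCCn1c2ccc([N+](=O)[O-])cc2c(=O)n1Cc1ccccc1`: > 256000 nM (a limit, not a number)
- Compound 3 `O=[N+]([O-])c1ccc2nn(Cc3ccccc3)c(OCCCBr)c2c1`: 59000 nM

Compound 3 gives 59000 nM, the lower of the two true numbers, and compound 1 gives 160000 nM. The value of compound 2 is a limit of the assay, > 256000 nM.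

Compound 4 `CCOC(=O)CCCOc1c2cc([N+](=O)[O-])ccc2nn1Cc1ccccc1` turns the 3-bromopropyl of compound 3 into 3-(ethoxycarbonyl)propyl: ethoxycarbonyl in place of bromo on a saturated chain carbon, three bonds along the chain from an oxygen on an aromatic ring.

Within the data shown here, no measured step makes this exact change. The closest guide is an at least 1.6-fold higher number from compound 1 to compound 2 (0.20 log units; that floor lies within the scatter), with 3-carbamoylpropyl in place of vinyl on an aromatic nitrogen. That step is a different change in a different place and rests on (the limit of > 256000 nM in this assay, at which 1 of the 3 values shown sits), so it supports only a cautious expectation of a rise in this assay. The expected step is a 1.9-fold higher number from compound 3 to compound 4 (0.27 log units; within the scatter). For compound 4 the estimated value is 110000 nM, with an expected range from 40000 nM to 256000 nM.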

Compound 4, concentration lethal to 50% of the cells: > 256000 nM
Compound 4: a limit, no number; the forecaster's own chance of this, stated with the estimate: 20%; middle value at least 2.3-fold (0.36 log units) from the limit.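

With the rest of the structure unchanged, ethoxycarbonyl in place of bromo at this chain end gives an at least 4.3-fold higher number from compound 3 to compound 4 (0.63 log units; beyond the scatter) in this assay. The earlier step changed a different group in a different place and its floor lay within the scatter, whereas this floor lies beyond it, so the group at the end of this chain clearly matters in this assay. The true size of the step remains unknown, and only its lower bound can be read: the limit of > 256000 nM in this assay, at which 2 of the 4 values shown sit.

On these data alone, what stays open is whether the rise comes from losing the bromo or from gaining the ester. A plain propyl chain with no end group, or a chain ending in a carboxylic acid or an amine, would help separate those two readings.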